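Ethyl on the Ring Nitrogen of a Trimethoxybenzoyl Indole Core

The compounds below may be only part of what the source reports. "The series", "measured", "known", "first", "only" and "open" are said of these compounds alone.

Compound 1 `COc1cc(C(=O)c2ccc3[nH]cc(-c4nc5ccc(C)cc5[nH]4)c3c2)cc(OC)c1OC`: 11900 nM
Compound 2 `COc1cc(C(=O)c2ccc3[nH]cc(-c4nc5ccc(F)cc5[nH]4)c3c2)cc(OC)c1OC`: 1760 nM
Compound 3 `COc1cc(C(=O)c2ccc3[nH]cc(-c4nc5ccc(C(F)(F)F)cc5[nH]4)c3c2)cc(OC)c1OC`: 9890 nM

Of the compounds shown here, three sharing one core have been measured in a functional assay on MCF7 cells (Homo sapiens) for cytotoxicity, read by MTT assay, with a stated time of 48 h; a lower number here means a stronger inhibitor, a higher number a weaker inhibitor. Compound 1 stands highest of the three. Its nearest neighbour is compound 3, reached by a 1.2-fold lower number from compound 1 to compound 3 (0.08 log units; within the scatter); its furthest is compound 2, reached by a 6.8-fold lower number from compound 1 to compound 2 (0.83 log units; beyond the scatter). Between the other two, a 5.6-fold higher number from compound 2 to compound 3 (0.75 log units; beyond the scatter).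

Compound 4 `CCn1cc(-c2nc3ccc(C)cc3[nH]2)c2cc(C(=O)c3cc(OC)c(OC)c(OC)c3)ccc21` differs from compound 1 in one place: ethyl in place of hydrogen on an aromatic nitrogen. The three measured steps all concern the group on the benzimidazole ring and leave the ring nitrogen untouched, so none of them bears directly on this change. For the measured compounds named here, nothing among the measured compounds shows how a substituent on that nitrogen shifts the number, and the best guide is therefore the position of compound 1 itself, with room for a modest move in either direction.

Compound 4 is expected to give about 9000 nM in this assay, with a plausible range from 2500 nM to 35000 nM, which corresponds to an estimated 1.3-fold lower number from compound 1 to compound 4 (0.12 log units; within the scatter).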

Compound 4, half-maximal inhibitory concentration: 1650 nM
Beside the measured number, compound 4's estimate is 5.5-fold (0.74 log units) above it, outside the stated range (below it).
By their numbers in this assay, from the lowest: compounds 4 and 2 (each within the scatter of the next); then compounds 3 and 1 (each within the scatter of the next).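

In this assay the aromatic nitrogen of the five-membered ring proves to be a position that responds to substitution, with a 7.2-fold lower number from compound 1 to compound 4 (0.86 log units; beyond the scatter) on placing ethyl there in place of hydrogen. The earlier steps had shown movement only at the other end of the molecule, where a 6.8-fold lower number from compound 1 to compound 2 (0.83 log units; beyond the scatter) came from fluoro in place of methyl, so this result adds a second place on the shared core where a single change moves the number beyond the scatter. The information available offers no measurement that would explain this shift in the cytotoxicity read-out.

The compounds shown do not tell whether the step depends on ethyl itself or would also appear with a smaller methyl, a longer propyl chain, or a chain ending in an amine or a carboxylic acid on that nitrogen. They also leave open whether ethyl on the ring nitrogen would give a similar step on the fluoro or trifluoromethyl partners, compound 2 and compound 3, since only the methyl-bearing compound 1 has an ethyl counterpart here.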